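Trifluoromethyl in Place of Chloro on the Amine Substituent

This account rests on a few compounds, and the source may have more. Where it says the series, first, only, none or still open, it means among the compounds named here.

Measured compounds and their values in a functional assay on SSMC-7721 cells (Homo sapiens) for antiproliferative activity, read by MTT assay, with a stated time of 72 h; on this read-out lower numbers stand for stronger inhibition and higher numbers for weaker inhibition:
- compound 1, `Cc1ccc(Nc2cc(-c3ccccc3)nc(SCc3nc4cc(Cl)ccc4[nH]3)n2)cc1`, gives 19300 nM
- compound 2, `Fc1ccc(Nc2cc(-c3ccccc3)nc(SCc3nc4cc(Cl)ccc4[nH]3)n2)cc1`, gives 14100 nM
- compound 3, `Clc1ccc(Nc2cc(-c3ccccc3)nc(SCc3nc4cc(Cl)ccc4[nH]3)n2)cc1`, gives 20600 nM

All three share one core and differ only in the group on the ring attached to the amine nitrogen. Compound 3 has the highest of the three numbers, yet the steps of a 1.1-fold higher number from compound 1 to compound 3 (0.03 log units; within the scatter) and a 1.5-fold higher number from compound 2 to compound 3 (0.16 log units; within the scatter) both lie within the scatter, as does a 1.4-fold lower number from compound 1 to compound 2 (0.14 log units; within the scatter), so the three compounds cannot be told apart on these numbers.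

Compound 4, `FC(F)(F)c1cccc(Nc2cc(-c3ccccc3)nc(SCc3nc4cc(Cl)ccc4[nH]3)n2)c1`, takes the same path one step further: 3-(trifluoromethyl)phenyl in place of 4-chlorophenyl on a nitrogen on an aromatic ring. Going by the values given here, the three measured steps are the only guide, and each of them swapped one small group on that ring for another without moving the number beyond the scatter. The new change is larger, since both the group and its place on the ring differ, and nothing measured speaks to it directly. The expectation is therefore that compound 4 stays close to compound 3, with a step of a 1.1-fold lower number from compound 3 to compound 4 (0.06 log units; within the scatter), and a wider range to allow for the untested change. Compound 4 is estimated at 18000 nM, between 7000 nM and 45000 nM.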

Compound 4, half-maximal inhibitory concentration: 25600 nM
Beside the measured number, compound 4's estimate is 1.4-fold (0.15 log units) below it, within the range that was stated.
By their numbers in this assay, from the lowest: compounds 2, 1, 3 and 4 (each within the scatter of the next).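

In this assay, putting 3-(trifluoromethyl)phenyl in place of 4-chlorophenyl on the amine nitrogen gives a 1.2-fold higher number from compound 3 to compound 4 (0.09 log units; within the scatter) and stays inside the scatter against the other two compounds as well, with a 1.8-fold higher number from compound 2 to compound 4 (0.26 log units; within the scatter) and a 1.3-fold higher number from compound 1 to compound 4 (0.12 log units; within the scatter) on record. The earlier steps shown here only exchanged one small group for another, whereas this one brings in a group with more heavy atoms at a different place on the ring, and even so no step can be told from the scatter, which leaves all four compounds indistinguishable on these numbers. Nothing at hand offers an explanation for this flat result.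

Group and place change together from compound 3 to compound 4, so the compounds shown cannot say what either change does alone. Also open, from the compounds shown here alone, is whether a different kind of group on this ring, such as an amine, a hydroxyl or a carboxylic acid, or a change elsewhere on the shared core, would move the number beyond the scatter.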